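Adding phenyl to the side chain of compound 2

A few compounds are considered here, and "the series" means these few. Any claim that something is new, unique, unknown or untested is made for them only; others in the source may bear on it.

Compound 1 (`CCCCCCOc1ccc2c(Cl)ccnc2c1`) gives 2420 nM
Compound 2 (`CCOc1ccc2c(Cl)ccnc2c1`) gives 2660 nM

Both values come from a functional assay on HepG2 cells (Homo sapiens) for cytotoxicity, read by MTT assay, with a stated time of 48 h (on this read-out higher numbers stand for weaker inhibition and lower numbers for stronger inhibition), and lie within the scatter of each other. For the measured compounds named here, compound 2 at 2660 nM has compound 1 as its only measured neighbour. Compound 3 (`Clc1ccnc2cc(OCCc3ccccc3)ccc12`) differs from compound 2 in one place, by phenyl in place of hydrogen on a saturated chain carbon, two bonds along the chain from an oxygen on an aromatic ring and nothing else. Going by the values given here, one measured step bears on this place: a 1.1-fold higher number from compound 1 to compound 2 (0.04 log units; within the scatter) with hydrogen in place of butyl on that same chain carbon. Among the compounds with values here, no measured compound carries phenyl there, so that step is only a loose guide. In this assay no change beyond the scatter is therefore expected, and the estimated step is a 1.2-fold lower number from compound 2 to compound 3 (0.06 log units; within the scatter) in all. Compound 3 is estimated at 2300 nM with an expected range of 1000 nM to 5000 nM for the coming measurement.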

Compound 3, half-maximal inhibitory concentration: 3310 nM
The estimate for compound 3 lay 1.4-fold (0.16 log units) below the measured number; the measured number falls inside the stated range.
By their numbers in this assay, from the lowest: compounds 1, 2 and 3 (each within the scatter of the next).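

In this assay, an aromatic ring on this saturated chain carbon, two bonds along the chain from an oxygen on an aromatic ring, leaves the number within the scatter (a 1.2-fold higher number from compound 2 to compound 3 (0.09 log units; within the scatter)). Phenyl set against butyl at the same carbon also stays within the scatter (a 1.4-fold higher number from compound 1 to compound 3 (0.14 log units; within the scatter)), so this read-out does not tell hydrogen, butyl and phenyl apart at this place. Nothing measured here offers an explanation for this result.

Going by these compounds, it remains open whether this holds for a group of another kind at this place, such as an amine or a carboxylic acid. On these data alone, it is also open whether a substituted phenyl, or a longer chain carrying the phenyl, would stay within the scatter of these three compounds.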